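The compounds below may be only part of what the source reports. "The series", "measured", "known", "first", "only" and "open" are said of these compounds alone.

Measured compounds in a functional assay on A549 cells (Homo sapiens) for cytotoxicity, read by sulforhodamine B assay, with a stated time of 48 h; a higher number here means that more compound is tolerated, a lower number that less compound is tolerated:
Compound 1 `ClCc1ccc(Cn2cnc3nc(Cl)nc(Cl)c32)cc1` gives 7940 nM.
Compound 2 `ClCc1ccccc1Cn1cnc2ncnc(Cl)c21` gives a limit of the assay, > 100000 nM.
Compound 3 `ClCc1ccccc1Cn1cnc2nc(Cl)nc(Cl)c21` gives a limit as well, > 100000 nM.

Compound 1 stands alone with a number; the other two values sit at the limit of > 100000 nM in this assay, at which 2 of the 3 values shown sit. The cores of compound 1 and compound 3 are built from the same atoms joined differently, and the difference between the two cores is not broken down here. Within the core of compound 3 the change hydrogen in place of chloro on an aromatic carbon gives a step that the two limits leave unreadable from compound 3 to compound 2, so its size is not readable.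

The same change, (hydrogen in place of chloro on an aromatic carbon), carries compound 1 to compound 4 `ClCc1ccc(Cn2cnc3ncnc(Cl)c32)cc1`. Among the measured compounds shown here, since the only measured instance is unreadable, the expectation rests on compound 1 alone at 7940 nM. Compound 4 is expected near 40000 nM, with the step of a 5.0-fold higher number from compound 1 to compound 4 (0.70 log units; beyond the scatter) estimated loosely and a fair chance of a limit only.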

Compound 4, concentration lethal to 50% of the cells: 9330 nM
Compound 4: middle estimate off by 4.3-fold (0.63 log units), on the high side; the measured number falls inside the stated range.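

In this assay, hydrogen in place of chloro on an aromatic carbon gives a 1.2-fold higher number from compound 1 to compound 4 (0.07 log units; within the scatter), so on this core the change leaves the number within the usual scatter. On the core of compound 3 the same change cannot be read, as compound 3 and compound 2 both sit at a limit and not at a number: the limit of > 100000 nM in this assay, at which 2 of the 4 values shown sit. This leaves one readable instance, which does not show whether the change behaves alike on both cores.

Only chloro and hydrogen appear on the aromatic carbon between two ring nitrogen atoms. The compounds shown leave open what an amine or a methoxy group there would do to the number.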